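Changing the Aryl Group on the Ring Nitrogen

This account rests on a few compounds, and the source may have more. Where it says the series, first, only, none or still open, it means among the compounds named here.

Compound 1, `CCC(C(=O)N1CCN(c2cccc(OC)c2)CC1)N1C(=O)CCC1=O`: 25%
Compound 2, `CCC(C(=O)N1CCN(c2ccc(F)cc2)CC1)N1C(=O)CCC1=O`: 0%
Compound 3, `CCC(C(=O)N1CCN(c2ccccc2F)CC1)N1C(=O)CCC1=O`: 100%

In a functional assay on the whole organism (strain Swiss) with Mus musculus as the target, in the maximal electroshock model, with a stated time of 0.25 h, at a dose of 300 mg/kg by the intraperitoneal route (on this read-out lower numbers stand for a weaker effect and higher numbers for a stronger effect at the one dose given), compound 3 stands highest of the three numbers, with steps a number 75 percentage points higher from compound 1 to compound 3 (beyond the scatter) and a number 100 percentage points higher from compound 2 to compound 3 (beyond the scatter), both beyond the scatter. Compound 4, `CCC(C(=O)N1CCN(c2ccc(Cl)cc2)CC1)N1C(=O)CCC1=O`, differs from compound 3 by 4-chlorophenyl in place of 2-fluorophenyl on an amine nitrogen in a ring. The step that bears on this change is a number 100 percentage points higher from compound 2 to compound 3 (beyond the scatter), a large one, because compound 2 carries a 4-fluorophenyl group at the same place and gives 0%. Going back to a 4-substituted phenyl is therefore expected to bring a large step downward, a number 75 percentage points lower from compound 3 to compound 4 (beyond the scatter), though no measured pair tells chlorine from fluorine, so the range is wide. Compound 4 is expected to give 25%, between 0% and 75%.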

Compound 4, a percentage reported as activity, at one dose (the size of the read-out at that dose, not a potency): 0%
Beside the measured number, compound 4's estimate is 25 percentage points above it, and the stated range covers the measured number.
By their numbers in this assay, from the lowest: compounds 2 and 4 (each within the scatter of the next); then compound 1; then compound 3.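

Swapping fluoro for chloro on the aromatic carbon gives no change at the digits printed from compound 2 to compound 4 (within the scatter), so at this one dose 4-chlorophenyl and 4-fluorophenyl cannot be told apart, which the earlier compounds could not show. A second compound with a halogen in its 4-substituted phenyl group now falls well short of the 2-fluorophenyl compound, with a number 100 percentage points lower from compound 3 to compound 4 (beyond the scatter), and also gives a number 25 percentage points lower from compound 1 to compound 4 (beyond the scatter). Nothing measured here explains these differences. Still open, from the compounds shown here alone, is how a 2-chlorophenyl or 2-methoxyphenyl group would compare with the 2-fluorophenyl group of compound 3. Going by these compounds, an unsubstituted phenyl group is also open.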